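Adding a Group on the Ring Nitrogen of Compound 1

The source may hold more compounds than are shown below. What is called first, only, known or untested is meant among the compounds shown, and "the series" means these compounds.

Of the compounds shown here, three that share a common core have been tested in a functional assay on HL-60 cells (Homo sapiens) for antiproliferative activity, with a stated time of 24 h; on this read-out lower numbers stand for stronger inhibition and higher numbers for weaker inhibition. Compound 1 `NC(=O)c1c(NC(=O)c2ccccc2Cl)sc2c1CCNC2` gives 18600 nM in this assay. Compound 2 `NC(=O)c1c(NC(=O)c2ccccc2F)sc2c1CCN(Cc1ccc(Cl)cc1Cl)C2` gives 13100 nM, and compound 3 `NC(=O)c1c(NC(=O)c2cccc([N+](=O)[O-])c2)sc2c1CCN(Cc1ccc(Cl)cc1Cl)C2` gives 19800 nM. Among these three numbers compound 1 stands second highest; all three lie within the usual scatter of one another, so none of them can be told apart with confidence.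

Compound 4 `NC(=O)c1c(NC(=O)c2ccccc2Cl)sc2c1CCN(C(=S)Nc1ccccc1F)C2` has not yet been measured. It differs from compound 1 in one place: a group of 10 heavy atoms (7 carbon, 1 nitrogen, 1 fluorine, 1 sulfur; one six-membered aromatic ring of carbon only) in place of a hydrogen atom, on an amine nitrogen in a ring.

Going by the values given here, only one single-point step has been measured here, a 1.5-fold higher number from compound 2 to compound 3 (0.18 log units; within the scatter), and it concerns the aryl ring attached to the carbonyl carbon, not the ring nitrogen where compound 4 is changed. Compound 2 and compound 3 do carry a group on that ring nitrogen, but they also differ from compound 1 at the carbonyl aryl, so their numbers only show that such substitution did not move the read-out beyond the scatter. From this thin evidence, no step beyond the scatter is expected in this assay; the estimated step is a 1.2-fold lower number from compound 1 to compound 4 (0.09 log units; within the scatter). Compound 4 is therefore expected to give about 15000 nM, somewhere between 5000 nM and 45000 nM.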

Compound 4, half-maximal inhibitory concentration: 4970 nM
Beside the measured number, compound 4's estimate is 3.0-fold (0.48 log units) above it; the whole stated range lies above it.
By their numbers in this assay, from the lowest: compound 4; then compounds 2, 1 and 3 (each within the scatter of the next).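

In this assay, placing the group of 10 heavy atoms on the amine nitrogen in the ring, where compound 1 carries a hydrogen atom, gives a 3.7-fold lower number from compound 1 to compound 4 (0.57 log units; beyond the scatter), a modest step but one that lies beyond the scatter. Going by these compounds alone, this is the first measured single change at this nitrogen and the first step in the set to exceed the scatter, since the only earlier step concerned the aryl ring on the carbonyl carbon and stayed within it; the hydrogen atom here can therefore be replaced with a gain in inhibition, at least by this group. No measurement available here accounts for the step, so the reason for it remains unknown.

Going by these compounds, it remains open which part of the entering group matters: a plain benzyl group or an acetyl group on this nitrogen, or versions of the group with oxygen in place of sulfur or hydrogen in place of fluorine, would help separate the contributions of its parts. On these data alone, it also remains open whether the same step would appear with the 2-fluorophenyl or 3-nitrophenyl group of compound 2 and compound 3 on the carbonyl carbon.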